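From Chloro to Cyano on an Aromatic Ring

The source may hold more compounds than are shown below. What is called first, only, known or untested is meant among the compounds shown, and "the series" means these compounds.

Among the compounds with values here, in a functional assay on BGC-823 cells (Homo sapiens) for antiproliferative activity, read by MTT assay, with a stated time of 48 h (on this read-out higher numbers stand for weaker inhibition and lower numbers for stronger inhibition), compound 1 (`CCn1cc(-c2nc3ccc([N+](=O)[O-])cc3o2)c(=O)c2cc(F)c(N3CCNC(C)C3)c(F)c21`) gives 2740 nM and holds the lowest of the three numbers so far. Compound 2 (`CCn1cc(-c2ccc(F)cc2)c(=O)c2cc(F)c(N3CCNCC3)cc21`) gives 69600 nM and holds the highest. Compound 3 (`CCn1cc(-c2ccc(Cl)cc2)c(=O)c2cc(F)c(N3CCNCC3)cc21`) gives 14600 nM and stands in the middle, with the second highest number and so a weaker result than compound 1.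

Compound 4 (`CCn1cc(-c2ccc(C#N)cc2)c(=O)c2cc(F)c(N3CCNCC3)cc21`) has not yet been measured. It differs from compound 3 in one place, on an aromatic carbon para to a large group, where cyano takes the place of chloro: cyano in place of chloro on an aromatic carbon. In other words, 4-chlorophenyl becomes 4-cyanophenyl.

Within the data shown here, one measured step bears on this change, the swap of fluoro for chloro on an aromatic carbon: a 4.8-fold lower number from compound 2 to compound 3 (0.68 log units; beyond the scatter). Among the measured compounds shown here, that modest step shows that the number can move when this group changes, but no measured compound carries cyano, so it cannot give the direction for this swap. Compound 1 differs from compound 3 in too many places to help.

In this assay the estimate therefore expects a 1.4-fold higher number from compound 3 to compound 4 (0.14 log units; within the scatter) and no shift beyond the scatter. For compound 4 the estimated value is 20000 nM within an expected range of 6000 nM to 70000 nM.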

Compound 4, half-maximal inhibitory concentration: 18700 nM
Compound 4: middle estimate off by 1.1-fold (0.03 log units), on the high side; the range from low to high includes it.
By their numbers in this assay, from the lowest: compound 1; then compounds 3 and 4 (each within the scatter of the next); then compound 2.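

In this assay, placing cyano instead of chloro on this aromatic carbon, para to a large group, gives a 1.3-fold higher number from compound 3 to compound 4 (0.11 log units; within the scatter) and so leaves the two groups indistinguishable in this measurement, even though cyano brings one more heavy atom and a hydrogen-bond acceptor that chloro lacks. The earlier compounds showed only that this position responds to a change of group, and compound 4 now adds that the response is not unique to chloro: a 3.7-fold lower number from compound 2 to compound 4 (0.57 log units; beyond the scatter) stands beside a 4.8-fold lower number from compound 2 to compound 3 (0.68 log units; beyond the scatter) as a second step away from fluoro that lies beyond the scatter, so among these three groups fluoro alone stands apart. No measurement shown here offers a reason for this pattern.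

From the compounds shown here alone, with only fluoro, chloro and cyano at this position, it remains open whether a quite different group there, such as an amine, a carboxylic acid or a longer chain, would move the number further in either direction. It is also open whether the same pattern among these three groups would hold on a different core, such as the core of compound 1.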